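From 3-methoxyphenyl to 4-methoxyphenyl: a small step expected

The source may hold more compounds than are shown below. What is called first, only, known or untested is meant among the compounds shown, and "the series" means these compounds.

Measured in a functional assay on A549 cells (Homo sapiens) for inhibition, read by MTT assay, with a stated time of 24 h; a higher number here means a weaker inhibitor, a lower number a stronger inhibitor:
- compound 1 `CC1(C)[C@H]2CC[C@]1(C)N(Cc1cn(-c3ccccc3O)nn1)C(=O)C2` gives 230 nM
- compound 2 `CC1(C)[C@H]2CC[C@]1(C)N(Cc1cn(-c3cccc(Br)c3)nn1)C(=O)C2` gives 90 nM
- compound 3 `COc1cccc(-n2cc(CN3C(=O)C[C@@H]4CC[C@@]3(C)C4(C)C)nn2)c1` gives 240 nM

The numbers for compound 1 and compound 3 cannot be told apart, as a 1.0-fold higher number from compound 1 to compound 3 (0.02 log units; within the scatter) shows. Compound 2 stands apart from compound 3, and the size of that gap is a 2.7-fold higher number from compound 2 to compound 3 (0.43 log units; beyond the scatter).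

Compound 4 `COc1ccc(-n2cc(CN3C(=O)C[C@@H]4CC[C@@]3(C)C4(C)C)nn2)cc1` keeps the shared core and carries 4-methoxyphenyl in place of 3-methoxyphenyl on an aromatic nitrogen. Within the data shown here, no measured pair tests this exact change, so the nearest guide is the other swaps at the same place. One of these, a 1.0-fold higher number from compound 1 to compound 3 (0.02 log units; within the scatter), made no real difference, and the other, a 2.6-fold lower number from compound 1 to compound 2 (0.41 log units; beyond the scatter), was only modest. Even fuller swaps of the group therefore moved the number little, so no step beyond the scatter is expected in this assay, and no direction can be favoured. The expected change is a 1.1-fold lower number from compound 3 to compound 4 (0.04 log units; within the scatter). For compound 4 the estimated value is 220 nM, with an expected range of 90 nM to 520 nM.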

Compound 4, half-maximal inhibitory concentration: 50 nM
The estimate for compound 4 lay 4.4-fold (0.64 log units) above the measured number; measured number outside the range, below it.
By their numbers in this assay, from the lowest: compounds 4 and 2 (each within the scatter of the next); then compounds 1 and 3 (each within the scatter of the next).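

Moving the methoxy group, with the same atoms joined differently, gives a 4.8-fold lower number from compound 3 to compound 4 (0.68 log units; beyond the scatter) in this assay, so this position responds to where a group sits on the phenyl ring and not only to which group is present. The 4-methoxyphenyl group also gives a 4.6-fold lower number from compound 1 to compound 4 (0.66 log units; beyond the scatter), while a 1.8-fold lower number from compound 2 to compound 4 (0.26 log units; within the scatter) leaves 4-methoxyphenyl and 3-bromophenyl indistinguishable, so two different groups in different places on the ring can reach similar numbers. No measurement is available to explain the effect of moving the methoxy group.

From the compounds shown here alone, whether the same move would matter for other groups remains open, as the 3-bromophenyl group has no 4-bromophenyl partner here. Going by these compounds, how 2-methoxyphenyl, or a phenyl ring carrying an amine or a carboxylic acid at the 4-position, would read in this assay also remains open.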